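A 3-methyl-1,2-oxazol-5-yl group replaces thiophen-3-yl

The source may hold more compounds than are shown below. What is called first, only, known or untested is meant among the compounds shown, and "the series" means these compounds.

Measured in a functional assay on U-373MG ATCC cells for inhibition, with U373 MG (Homo sapiens) as the target, read by MTT assay, with a stated time of 7 days; a lower number here means a stronger inhibitor of growth, a higher number a weaker inhibitor of growth:
Compound 1 `C[Si](C)(C)Cn1nnc2c(C(N)=O)ncn2c1=O`: 45600 nM
Compound 2 `NC(=O)c1ncn2c(=O)n(Cc3ccco3)nnc12`: > 50000 nM (a limit)
Compound 3 `NC(=O)c1ncn2c(=O)n(Cc3ccsc3)nnc12`: > 50000 nM (a limit)

Compound 3 gives > 50000 nM, which is a limit and not a number. It stands at the limit of > 50000 nM in this assay, at which 2 of the 3 values shown sit. Compound 4 `Cc1cc(Cn2nnc3c(C(N)=O)ncn3c2=O)on1` differs from it as follows: 3-methyl-1,2-oxazol-5-yl in place of thiophen-3-yl on a saturated chain carbon bound to an aromatic nitrogen.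

Within the data shown here, three measured steps bear on this change. The closest exchange of one ring for another is a step that the two limits leave unreadable from compound 2 to compound 3. The others are an at least 1.0-fold higher number from compound 1 to compound 2 (0.04 log units; that floor lies within the scatter) and an at least 1.0-fold higher number from compound 1 to compound 3 (0.04 log units; that floor lies within the scatter). Among the measured compounds shown here, none of them shows a change beyond the scatter, so no step of readable size is expected in this assay, and no direction can be given. The expected change is a number no higher from compound 3 to compound 4 (the limit leaves the size open). For compound 4 the estimate is 50000 nM, with an expected range from 30000 nM to 100000 nM.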

Compound 4, concentration for 50% growth inhibition: > 50000 nM
Compound 4: no number, only a limit; the forecaster's own chance of this, stated with the estimate: 75%; the middle value lies on the limit itself.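

In this assay compound 4 gives > 50000 nM, again a limit, so a 3-methyl-1,2-oxazol-5-yl group, with its two ring hetero atoms, gives no readable number at this place either: the limit of > 50000 nM in this assay, at which 3 of the 4 values shown sit. Among these compounds, the one step that can be read is an at least 1.0-fold higher number from compound 1 to compound 4 (0.04 log units; that floor lies within the scatter). The steps from compound 2 and from compound 3 to compound 4 cannot be read. From the compounds shown here alone, whether a longer chain, or a ring carrying an amine, on the saturated chain carbon would give a number rather than a limit stays open.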